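Isobutyl for isopropyl in a thiourea pair

The source may hold more compounds than are shown below. What is called first, only, known or untested is meant among the compounds shown, and "the series" means these compounds.

Measured in a functional assay on A549 cells (Homo sapiens) for cytotoxicity, read by MTT assay; on this read-out higher numbers stand for weaker inhibition and lower numbers for stronger inhibition:
- compound 1 `CC(C)[C@H](NC(=S)Nc1cc(C(F)(F)F)cc(C(F)(F)F)c1)c1nc2ccccc2[nH]1`: 25100 nM
- compound 2 `CC(C)C[C@@H](NC(=S)Nc1ccccc1)c1nc2ccccc2[nH]1`: 18700 nM

The two measured compounds give numbers within the scatter of each other, so compound 1 has no separate standing on these data. Both values lie in the same narrow band, and two compounds are too few to show any trend.

Compound 3 `CC(C)C[C@H](NC(=S)Nc1cc(C(F)(F)F)cc(C(F)(F)F)c1)c1nc2ccccc2[nH]1` keeps the structure of compound 1 except for one change: isobutyl in place of isopropyl on a saturated chain carbon bound to an amide-type nitrogen and an aromatic carbon.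

For the measured compounds named here, no measured pair isolates this change. In this assay, no step beyond the scatter is expected. The expected change is a 1.3-fold lower number from compound 1 to compound 3 (0.12 log units; within the scatter).

For compound 3 the estimated value is 19000 nM, with an expected range of 8000 nM to 42000 nM.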

Compound 3, half-maximal inhibitory concentration: 17400 nM
Estimate against measurement, compound 3: 1.1-fold (0.04 log units) above; the range from low to high includes it.
By their numbers in this assay, from the lowest: compounds 3, 2 and 1 (each within the scatter of the next).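

In this assay, for the compounds shown here, isobutyl in place of isopropyl on a saturated chain carbon bound to an amide-type nitrogen and an aromatic carbon gives the first single-change pair of the series. The pair shows a 1.4-fold lower number from compound 1 to compound 3 (0.16 log units; within the scatter) and so adds a direct reading at this position: with the rest of compound 1 held fixed, going from 3 to 4 heavy atoms in this group leaves the number within the scatter. No measured evidence accounts for this result.

From the compounds shown here alone, whether a longer chain such as n-hexyl, a cyclohexyl ring, or a carboxylic acid at this carbon would move the number beyond the scatter remains open. Also open, going by these compounds, is whether the same isopropyl-to-isobutyl change would read alike with the unsubstituted phenyl group of compound 2 on the thiourea.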